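Swapping 4-Methylbenzyl for Phenyl on the Amide Nitrogen

A few compounds are considered here, and "the series" means these few. Any claim that something is new, unique, unknown or untested is made for them only; others in the source may bear on it.

Among the compounds with values here, in a functional assay on SW480 cells (Homo sapiens) for cytotoxicity, read by MTT assay, with a stated time of 48 h (on this read-out higher numbers stand for weaker inhibition and lower numbers for stronger inhibition), compound 1 (`COc1cc([C@@H]2C[C@]2(CO)C(=O)NCc2ccc(C)cc2)cc(OC)c1OC`) gives 26800 nM and so holds the lower, stronger of the two numbers measured so far. Within the data shown here, compound 2 (`COc1cc([C@@H]2C[C@@]2(CO)C(=O)NCc2ccc(C)cc2)cc(OC)c1OC`) gives 76300 nM as the only other number.

Among the measured compounds shown here, compound 3 (`COc1cc([C@@H]2C[C@]2(CO)C(=O)Nc2ccccc2)cc(OC)c1OC`) keeps the core of compound 1 but carries phenyl in place of 4-methylbenzyl on an amide-type nitrogen as its one change. For the measured compounds named here, the only measured step is a 2.8-fold higher number from compound 1 to compound 2 (0.45 log units; beyond the scatter) and it reflects the fact that compounds 1 and 2 differ only in the configuration as drawn rather than any change of this group. Going by the values given here, that step therefore offers a rough yardstick for size but no guide to direction, since no measured pair alters the group on the nitrogen.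

A small shift is the cautious expectation, and the expected step in this assay is a 1.3-fold higher number from compound 1 to compound 3 (0.12 log units; within the scatter) with little confidence in its direction. Compound 3 is estimated at 35000 nM with an expected range from 12000 nM to 100000 nM around that middle.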

Compound 3, half-maximal inhibitory concentration: 33300 nM
Compound 3: the middle estimate sits 1.1-fold (0.02 log units) above what was measured; measured number inside the range.
By their numbers in this assay, from the lowest: compounds 1 and 3 (each within the scatter of the next); then compound 2.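

Putting phenyl in place of 4-methylbenzyl on the amide-type nitrogen gives, in this assay, a 1.2-fold higher number from compound 1 to compound 3 (0.09 log units; within the scatter) and so leaves the read-out unchanged as far as the scatter can tell. Within the data shown here, this is the first measured change to the group on this nitrogen, and it shows that the anilino amide of compound 3 keeps the micromolar-range number of the (4-methylbenzyl)amino amide of compound 1, while the change of configuration between compound 1 and compound 2 remains the only single change here that moves the number beyond the scatter. Nothing in the information available explains why the number holds across this swap.

As far as these compounds go, what remains open is how far this tolerance extends on the nitrogen, for instance to a plain benzyl, a longer chain such as phenethyl, a pyridyl ring, or a phenyl carrying a carboxylic acid or an amine. From the compounds shown here alone, it is also open whether the gap between the two configurations seen with 4-methylbenzyl would reappear with phenyl on the nitrogen.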